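This account rests on a few compounds, and the source may have more. Where it says the series, first, only, none or still open, it means among the compounds named here.

Compound 3 `O=C(NC1CCN(Cc2cccc(C(F)(F)F)c2)CC1)c1cccc2ccccc12` gives 119 nM in an assay on isolated protein for displacement of a labelled ligand from D(4) dopamine receptor (Homo sapiens) (on this read-out higher numbers stand for weaker inhibition and lower numbers for stronger inhibition), which places it second highest of the three numbers measured. Compound 1 `O=C(NC1CCN(Cc2ccccc2Cl)CC1)c1cccc2ccccc12` gives 329 nM, while compound 2 `O=C(NC1CCN(Cc2ccc(Cl)cc2)CC1)c1cccc2ccccc12` gives 43 nM. Compound 4 `COc1ccc(CN2CCC(NC(=O)c3cccc4ccccc34)CC2)cc1` differs from compound 3 in one place: 4-methoxyphenyl in place of 3-(trifluoromethyl)phenyl on a saturated chain carbon bound to an amine nitrogen in a ring. Within the data shown here, two measured steps bear on this change: a 2.8-fold higher number from compound 2 to compound 3 (0.44 log units; beyond the scatter) and a 2.8-fold lower number from compound 1 to compound 3 (0.44 log units; beyond the scatter), both modest. Because a 2.8-fold higher number from compound 2 to compound 3 (0.44 log units; beyond the scatter) showed the number rising when 4-chlorophenyl gave way to 3-(trifluoromethyl)phenyl, a return to a 4-substituted phenyl of the kind carried by compound 2 is expected to lower the number in this assay by a modest step, a 2.0-fold lower number from compound 3 to compound 4 (0.30 log units; within the scatter). Compound 4 is therefore estimated at 60 nM, with a likely range from 25 nM to 150 nM.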

Compound 4, inhibition constant: 223 nM
For compound 4 the middle estimate is 3.7-fold (0.57 log units) below the measured one; the whole stated range lies below it.
By their numbers in this assay, from the lowest: compound 2; then compounds 3, 4 and 1 (each within the scatter of the next, the first and the last beyond it).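

Swapping only chloro for methoxy on the aromatic carbon of the benzyl-type group gives a 5.2-fold higher number from compound 2 to compound 4 (0.71 log units; beyond the scatter) in this assay, so keeping a group at the same ring position does not keep the number of compound 2; the identity of the group counts too. Compound 4 stays level with the other two, with a 1.9-fold higher number from compound 3 to compound 4 (0.27 log units; within the scatter) and a 1.5-fold lower number from compound 1 to compound 4 (0.17 log units; within the scatter). No supporting data explain the gap between chloro and methoxy. As far as these compounds go, whether an amine or a nitrile on that aromatic carbon would give a number closer to compound 2 or to compound 4 remains open.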